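The source may hold more compounds than are shown below. What is called first, only, known or untested is meant among the compounds shown, and "the series" means these compounds.

Compound 1 `CN(C[C@H]1Cc2c(cccc2N2CCN(C3CC3)CC2)CN1)[C@H]1CCCc2cccnc21` and compound 4 `CN(C[C@H]1Cc2c(cccc2N2CCN3CCC[C@H]3C2)CN1)[C@H]1CCCc2cccnc21` are built from the same atoms joined differently, and the account follows the move from the first to the second. In a functional assay on CCRF-CEM cells for agonist activity at C-X-C chemokine receptor type 4 (Homo sapiens), read by calcium flux, with a stated time of 25 min (a higher number here means that more compound is needed for the effect, a lower number that less compound is needed), compound 1 gives > 30000 nM, which is a limit of the assay rather than a number. Compound 2 `CN1CCN(c2cccc3c2C[C@H](CN(C)[C@H]2CCCc4cccnc42)N(C)C3)CC1` in this assay gives > 30000 nM, again a limit. Compound 3 `CN(C[C@H]1Cc2c(cccc2N2CCN(c3cccc(C(F)(F)F)c3)CC2)CN1)[C@H]1CCCc2cccnc21` in this assay gives > 30000 nM, also a limit. With every result capped in this way, compound 1 cannot be placed above or below its companions: the limit of > 30000 nM in this assay, at which 3 of the 3 values shown sit. Among the measured compounds shown here, the single step that shares a point of difference with the present one, a step that the two limits leave unreadable from compound 1 to compound 3, is for the same reason unreadable in both size and direction. Compound 4 differs from compound 1 by a group of 9 heavy atoms (7 carbon, 2 nitrogen; one five-membered non-aromatic ring with 1 hetero atom, one six-membered non-aromatic ring with 2 hetero atoms) in place of a group of 9 heavy atoms (7 carbon, 2 nitrogen; one three-membered non-aromatic ring of carbon only, one six-membered non-aromatic ring with 2 hetero atoms), on an aromatic carbon. For the measured compounds named here, no measured step speaks to this change, and the one related step is unreadable, so no size or direction is expected for a step that the limit leaves unreadable from compound 1 to compound 4 in this assay beyond a strong chance that compound 4 sits at the same limit. Compound 4 is therefore expected to give about 40000 nM in this assay, within a range from 10000 nM to 200000 nM, most probably reported as a limit rather than a number.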

Compound 4, half-maximal effective concentration: > 30000 nM
Compound 4 was reported as a limit (the forecaster's own chance of this, stated with the estimate: 85%); the middle value does not contradict the limit.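

No step can be read from compound 1 to compound 4 in this assay, because both compounds sit at a limit of the assay, as do the others shown: the limit of > 30000 nM in this assay, at which 4 of the 4 values shown sit.

The compounds shown leave open whether any group at this place on the shared core would give a number rather than a limit in this assay.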